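This account rests on a few compounds, and the source may have more. Where it says the series, first, only, none or still open, it means among the compounds named here.

Measured compounds:
compound 1, `O=c1[nH]cc(S(=O)(=O)Nc2ccccc2-c2cn(-c3ccccc3F)nn2)c(=O)[nH]1`, in a functional assay on A549 cells (Homo sapiens) for antiproliferative activity, read by MTT assay, with a stated time of 24 h (on this read-out lower numbers stand for stronger inhibition and higher numbers for weaker inhibition), compound 1 gives 7370 nM
compound 2, `O=c1[nH]cc(S(=O)(=O)Nc2ccccc2-c2cn(-c3cccc(F)c3)nn2)c(=O)[nH]1`, compound 2 gives 8130 nM
compound 3, `O=c1[nH]cc(S(=O)(=O)Nc2cccc(-c3cn(-c4ccccc4F)nn3)c2)c(=O)[nH]1`, compound 3 gives > 20000 nM, which is a limit of this assay, not a number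

Compound 1 and compound 2 share a core and differ by 3-fluorophenyl in place of 2-fluorophenyl on an aromatic nitrogen. That change made a 1.1-fold higher number from compound 1 to compound 2 (0.04 log units; within the scatter). The core of compound 3 is not that of compound 1, and the difference between the two cores is not broken down here. For compound 3 only the limit is known, (the limit of > 20000 nM in this assay, at which 1 of the 3 values shown sits).

Compound 4, `O=c1[nH]cc(S(=O)(=O)Nc2cccc(-c3cn(-c4cccc(F)c4)nn3)c2)c(=O)[nH]1`, is still to be measured in this assay. It differs from compound 3 by 3-fluorophenyl in place of 2-fluorophenyl on an aromatic nitrogen, the same change as between compound 1 and compound 2. Because that change gave a 1.1-fold higher number from compound 1 to compound 2 (0.04 log units; within the scatter), and because compound 3 sits at the limit of > 20000 nM in this assay, at which 1 of the 3 values shown sits, compound 4 is expected to show a step that the limit leaves unreadable from compound 3 to compound 4. Compound 4 is estimated at 30000 nM, between 12000 nM and 80000 nM, most likely reported again only as a limit.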

Compound 4, half-maximal inhibitory concentration: 7200 nM
For compound 4 the middle estimate is 4.2-fold (0.62 log units) above the measured one; the whole stated range lies above it.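

In this assay, 3-fluorophenyl in place of 2-fluorophenyl on the aromatic nitrogen gave an at least 2.7-fold lower number from compound 3 to compound 4 (0.44 log units; beyond the scatter) on the core of compound 3. The change therefore did not carry over unaltered from one core to the other: the same change on two cores in this assay, a 1.1-fold higher number (0.04 log units; within the scatter) from compound 1 to compound 2 and an at least 2.7-fold lower number (0.44 log units; beyond the scatter) from compound 3 to compound 4, at least 3.0-fold (0.48 log units) apart, beyond the scatter of two such steps. Compound 3 stands only at a limit, so the true size of this step stays unknown, and two cores neither explain the difference nor establish a rule for the series: the limit of > 20000 nM in this assay, at which 1 of the 4 values shown sits.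

The compounds shown leave open how a chlorophenyl, a methoxyphenyl or an unsubstituted phenyl group on that nitrogen would behave on these two cores. They also leave open whether an amine or a carboxylic acid on that phenyl ring would depend on the core in the same way.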